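The source may report more compounds than this note shows. Statements on the series, on what has been measured and on what is new or still open speak of the compounds shown alone.

Measured compounds in an assay on isolated protein for binding affinity to Leucine-rich repeat serine/threonine-protein kinase 2 (Homo sapiens), read by TR-FRET and LanthaScreen, with a stated time of 2 h; a higher number here means a weaker inhibitor, a lower number a stronger inhibitor:
compound 1, `C[C@@H]1CCCN1c1c(C#N)c2c(N)nc(N)nc2n1C`, gives 6 nM
compound 2, `C[C@@H]1CCCN1c1c(C#N)c2c(N)nc(Nc3cnn(C)c3)nc2n1C`, gives 0.1 nM

For the measured compounds named here, compound 2 stands lowest of the two numbers in this assay; its nearest neighbour is compound 1, and the only step between them, a 60-fold lower number from compound 1 to compound 2 (1.78 log units; beyond the scatter), is large and beyond the scatter. Compound 3, `Cc1nn(C)cc1Nc1nc(N)c2c(C#N)c(N3CCC[C@H]3C)n(C)c2n1`, differs from compound 2 by methyl in place of hydrogen on an aromatic carbon. Going by the values given here, no measured step bears on this change: the one step in hand concerns the pyrazole group itself, not a methyl on its ring carbon, so it gives no direction for compound 3. With nothing to anchor a shift in either direction, the number for compound 3 is expected to remain close to that of compound 2, the step of a 2.0-fold higher number from compound 2 to compound 3 (0.30 log units; within the scatter) being expected to fall within the scatter. The estimate for compound 3 in this assay is 0.2 nM, with a range from 0.05 nM to 1 nM.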

Compound 3, inhibition constant: 1 nM
Estimate against measurement, compound 3: 5.0-fold (0.70 log units) below, and the stated range covers the measured number.
By their numbers in this assay, from the lowest: compound 2; then compound 3; then compound 1.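

In this assay the methyl on the aromatic carbon next to the ring nitrogen gives a 10-fold higher number from compound 2 to compound 3 (1.00 log units; beyond the scatter) and so shows that this carbon of the five-membered ring is not indifferent to substitution, even for a single added carbon. The 1,3-dimethyl-1H-pyrazol-4-yl group still gives a 6.0-fold lower number from compound 1 to compound 3 (0.78 log units; beyond the scatter) but this is a smaller step than a 60-fold lower number from compound 1 to compound 2 (1.78 log units; beyond the scatter) so the methyl gives back part of the gain without removing it. Nothing at hand explains why the number moves at this position.

As far as these compounds go, whether an ethyl group, a methoxy group or a chlorine atom on the same carbon would move the number in the same direction remains open. So does whether a longer chain in place of the methyl on the ring nitrogen would be tolerated.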